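The compounds below may be only part of what the source reports. "The series", "measured", "known", "first", "only" and "open" are said of these compounds alone.

The series shares one core and varies the group on the carbonyl carbon. Compound 1 `O=C(/C=C\N(O)Cc1ccc(OCc2ccccc2)cc1)C1CC1` carries cyclopropyl there, and in an assay on RBL-1 cells for inhibition of Polyunsaturated fatty acid 5-lipoxygenase (Rattus norvegicus) (on this read-out lower numbers stand for stronger inhibition and higher numbers for weaker inhibition), compound 1 gives 2600 nM. Compound 2 `O=C(/C=C\N(O)Cc1ccc(-c2ccccc2)cc1)c1ccc(F)cc1` carries 4-fluorophenyl; in this assay compound 2 gives 3000 nM. Compound 3 `O=C(/C=C\N(O)Cc1ccc(-c2ccccc2)cc1)c1ccsc1` carries thiophen-3-yl; in this assay compound 3 gives 3000 nM. Compound 3 thus stands level with compound 2, and its distance from compound 1 lies within the scatter, so the three numbers cannot be ordered against each other.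

The next compound, compound 4 `O=C(/C=C\N(O)Cc1ccc(-c2ccccc2)cc1)C1CC1`, differs from compound 3 by cyclopropyl in place of thiophen-3-yl on a carbonyl carbon. For the measured compounds named here, the one measured step that bears on this change is the earlier swap of the group on the same carbonyl carbon, no change at the digits printed from compound 2 to compound 3 (within the scatter). Compound 1, which already carries cyclopropyl on its carbonyl carbon but differs from compound 4 elsewhere, gives a number within the scatter of compound 3. Nothing measured here points to a difference beyond the scatter, so for compound 4 in this assay the expected step is a 1.1-fold lower number from compound 3 to compound 4 (0.03 log units; within the scatter). Compound 4 is estimated at 2800 nM in this assay, with a range from 1200 nM to 6500 nM.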

Compound 4, half-maximal inhibitory concentration: 1200 nM
Estimate against measurement, compound 4: 2.3-fold (0.37 log units) above; low and high end bracket the measured number.
By their numbers in this assay, from the lowest: compound 4; then compounds 1, 2 and 3 (each within the scatter of the next).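

In this assay the group on the carbonyl carbon now makes a difference that can be read: cyclopropyl in place of thiophen-3-yl gives a 2.5-fold lower number from compound 3 to compound 4 (0.40 log units; beyond the scatter) and cyclopropyl in place of 4-fluorophenyl gives a 2.5-fold lower number from compound 2 to compound 4 (0.40 log units; beyond the scatter) where the swap between the two aromatic groups had given no change at the digits printed from compound 2 to compound 3 (within the scatter) within the scatter. For the compounds shown here, with cyclopropyl held on the carbonyl carbon, phenyl in place of benzyloxy on an aromatic carbon gives a 2.2-fold lower number from compound 1 to compound 4 (0.34 log units; beyond the scatter) and so isolates a second place that registers, which the earlier compounds could not do, as compound 1 differs from compounds 2 and 3 in two places. No measurement at hand accounts for either step, and the reason for them remains unknown.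

Still open, on these data alone, is whether the lower number belongs to cyclopropyl alone or extends to other non-aromatic groups on the carbonyl carbon, such as methyl, cyclobutyl or a longer alkyl chain. Also open, as far as these compounds go, is how a carboxylic acid or an amine at that carbon would read, and whether a phenoxy group in place of phenyl on the aromatic carbon would fall with compound 1 or with compound 4.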